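A few compounds are considered here, and "the series" means these few. Any claim that something is new, unique, unknown or untested is made for them only; others in the source may bear on it.

Compound 1 `CCSCCn1c(=O)c2[nH]c(Cc3cccs3)nc2n(Cc2ccco2)c1=O`: 275 nM
Compound 2 `CCn1c(=O)c2[nH]c(Cc3ccccc3)nc2n(Cc2ccco2)c1=O`: 162 nM
Compound 3 `CCCn1c(=O)c2[nH]c(Cc3ccccc3)nc2n(Cc2ccco2)c1=O`: 117 nM

Of the compounds shown here, three have been measured in an assay on HEK293 cells for displacement of a labelled ligand from adenosine receptor A2b (Homo sapiens); on this read-out lower numbers stand for stronger inhibition and higher numbers for weaker inhibition. Compound 1 gives the highest of the three numbers; compound 2 lies within the scatter of compound 1, while compound 3 lies beyond it. Compound 4, `C#CCn1c(=O)c2[nH]c(Cc3cccs3)nc2n(Cc2ccco2)c1=O`, differs from compound 1 in one place: ethynyl in place of (ethylsulfanyl)methyl on a saturated chain carbon bound to an aromatic nitrogen. Among the compounds with values here, no measured step matches this change. Within the data shown here, the only single step available, a 1.4-fold lower number from compound 2 to compound 3 (0.14 log units; within the scatter), concerns lengthening a saturated chain and stays within the scatter, so it offers little guidance for removing a sulfur and introducing a triple bond. Nothing in these numbers points to a shift beyond the scatter. Compound 4 is therefore expected near 250 nM, between 100 nM and 650 nM. The estimated step is a 1.1-fold lower number from compound 1 to compound 4 (0.04 log units; within the scatter).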

Compound 4, inhibition constant: 269 nM
Compound 4: middle estimate off by 1.1-fold (0.03 log units), on the low side, and the stated range covers the measured number.
By their numbers in this assay, from the lowest: compounds 3, 2, 4 and 1 (each within the scatter of the next, the first and the last beyond it).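

Ethynyl in place of (ethylsulfanyl)methyl, on a saturated chain carbon bound to an aromatic nitrogen, leaves the number in this assay unmoved (a 1.0-fold lower number from compound 1 to compound 4 (0.01 log units; within the scatter)). This position therefore accepts a chain with a triple bond and a chain with a sulfur alike, which the earlier step, confined to saturated chains without sulfur, could not show. No evidence is available to explain this result.

Still open, from the compounds shown here alone, is how this read-out responds to an amine or a carboxylic acid at this chain's end. A longer chain, such as hexyl, is also untested among the compounds shown.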